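Trimming the Ether Side Chain of Compound 1

This account rests on a few compounds, and the source may have more. Where it says the series, first, only, none or still open, it means among the compounds named here.

Of the compounds shown here, three sharing one core have been tested in an ADME assay on HEL cells (Homo sapiens) for cytotoxicity, with a stated time of 3 days; on this read-out lower numbers stand for higher toxicity in this test and higher numbers for lower toxicity in this test. Compound 1 `CCC1(Cc2ccccc2)OS(=O)(=O)C=C1OCCCCc1ccccc1` gives 99000 nM. Compound 2 `CCC1(Cc2ccccc2)OS(=O)(=O)C=C1NCc1ccccc1` gives 92000 nM, a number within the scatter of that of compound 1. Compound 3 `CC(C)C1(Cc2ccccc2)OS(=O)(=O)C=C1OCc1ccccc1` gives 200000 nM, a higher number than compound 1 and beyond the scatter. Compound 1 therefore stands second highest of the three numbers, close to compound 2 and apart from compound 3.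

Compound 4 `C=CCOC1=CS(=O)(=O)OC1(CC)Cc1ccccc1` has not been measured. It differs from compound 1 in one place: vinyl in place of 3-phenylpropyl on a saturated chain carbon bound to an oxygen on an unsaturated carbon. Among the compounds with values here, no step between measured compounds shows this change, so its direction is uncertain. The step of a 1.5-fold higher number from compound 1 to compound 4 (0.18 log units; within the scatter) is expected to be small, toward a higher number if anything. Compound 4 is estimated at 150000 nM, between 60000 nM and 400000 nM.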

Compound 4, half-maximal cytotoxic concentration: > 200000 nM
Compound 4 gave a limit, no number (the forecaster's own chance of this, stated with the estimate: 20%); middle value at least 1.3-fold (0.12 log units) from the limit.
By their numbers in this assay, from the lowest: compounds 2 and 1 (each within the scatter of the next); then compound 3.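

In this assay compound 4 stands as a limit and not a number: the limit of > 200000 nM in this assay, at which 1 of the 4 values shown sits. Vinyl in place of 3-phenylpropyl, which takes the aromatic ring out of the side chain, gives an at least 2.0-fold higher number from compound 1 to compound 4 (0.30 log units; that floor lies within the scatter), so the true size of this step stays unknown. Allyloxy in place of benzylamino on a double-bonded ring carbon gives an at least 2.1-fold higher number from compound 2 to compound 4 (0.33 log units; beyond the scatter), which clears the scatter even as a floor.

As far as these compounds go, how far the number of compound 4 lies past its limit remains open. So does whether a saturated propyl chain or a terminal amine on this chain would read the same way.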